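Aryl for alkyl on the alkyne: an expected step

The compounds below may be only part of what the source reports. "The series", "measured", "known", "first", "only" and "open" are said of these compounds alone.

Measured compounds:
compound 1 `CCCCCc1ccc(C#Cc2cn(C/C=C\CN3C(=O)c4ccccc4C3=O)c(=O)[nH]c2=O)cc1`: > 100000 nM
compound 2 `CCCCCC#Cc1cn(C/C=C/CN2C(=O)c3ccccc3C2=O)c(=O)[nH]c1=O`: 58000 nM

Within the data shown here, in a functional assay on SW-620 cells (Homo sapiens) for antiproliferative activity, read by MTT assay, with a stated time of 3 days (on this read-out lower numbers stand for stronger inhibition and higher numbers for weaker inhibition), compound 2 gives 58000 nM, the only number among the values shown. For compound 1 the result is a limit of the assay, > 100000 nM (the limit of > 100000 nM in this assay, at which 1 of the 2 values shown sits). Compound 3 `CCCCCc1ccc(C#Cc2cn(C/C=C/CN3C(=O)c4ccccc4C3=O)c(=O)[nH]c2=O)cc1` has not been measured; it differs from compound 2 by 4-pentylphenyl in place of pentyl on a triple-bonded carbon. Among the measured compounds shown here, no measured pair here shows the effect of that exchange, so the expectation rests on little. Compound 3 is expected to give 90000 nM, within a range of 25000 nM to 300000 nM. The expected step of a 1.6-fold higher number from compound 2 to compound 3 (0.19 log units; within the scatter) is small, toward weaker inhibition, and a limit rather than a number is quite possible.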

Compound 3, half-maximal inhibitory concentration: 30000 nM
Beside the measured number, compound 3's estimate is 3.0-fold (0.48 log units) above it, and the stated range covers the measured number.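

In this assay, 4-pentylphenyl in place of pentyl on a triple-bonded carbon gives a 1.9-fold lower number from compound 2 to compound 3 (0.29 log units; within the scatter), so this position accepts the larger group without a change that can be told from scatter. Among these compounds, the only step here beyond the scatter is an at least 3.3-fold lower number from compound 1 to compound 3 (0.52 log units; beyond the scatter), and it goes with the double bond alone: the fact that compounds 1 and 3 differ only in the configuration as drawn. Compound 1 stands at a limit of the assay, not at a number: the limit of > 100000 nM in this assay, at which 1 of the 3 values shown sits.

As far as these compounds go, whether the same double-bond difference holds with pentyl on the alkyne remains open. So does the effect of an amine or a carboxylic acid at the end of that chain.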